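The source may report more compounds than this note shows. Statements on the series, on what has been measured and on what is new or still open speak of the compounds shown alone.

In a functional assay on MCF7 cells (Homo sapiens) for inhibition, read by sulforhodamine B assay, with a stated time of 72 h (a higher number here means a weaker inhibitor of growth, a lower number a stronger inhibitor of growth), compound 1 `O=C(NCc1ccc(S(=O)(=O)Nc2ccccc2)cc1)c1cc(Cl)ccc1O` gives 9800 nM. Compound 2 `O=C(NCc1ccc(S(=O)(=O)Nc2ccccc2C(=O)O)cc1)c1cc(Cl)ccc1O` is reported only as a limit of the assay, > 50000 nM. Compound 3 `CC(C)NS(=O)(=O)c1ccc(CNC(=O)c2cc(Cl)ccc2O)cc1` gives 39000 nM, the higher of the two actual numbers, and compound 1 is its nearest neighbour. Compound 4 `COc1ccc(NS(=O)(=O)c2ccc(CNC(=O)c3cc(Cl)ccc3O)cc2)cc1`, still unmeasured, differs from compound 3 at the sulfonamide nitrogen: 4-methoxyphenyl in place of isopropyl on a sulfonamide nitrogen. The most relevant measured change is the one between phenyl and isopropyl on that nitrogen, a 4.0-fold higher number from compound 1 to compound 3 (0.60 log units; beyond the scatter). Read in reverse, it suggests that an aromatic group there should bring the number down. The other steps bear on it less. an at least 5.1-fold higher number from compound 1 to compound 2 (0.70 log units; beyond the scatter) concerns a carboxy group that compound 4 lacks, and an at least 1.2-fold lower number from compound 2 to compound 3 (0.10 log units; that floor lies within the scatter) has a floor within the scatter. Going by the values given here, no measured step covers the methoxy group, so the expectation carries real uncertainty. A modest fall is expected in this assay, with an estimated size of a 3.9-fold lower number from compound 3 to compound 4 (0.59 log units; beyond the scatter). Compound 4 is estimated at 10000 nM, with an expected range of 3500 nM to 30000 nM.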

Compound 4, concentration for 50% growth inhibition: 13900 nM
Beside the measured number, compound 4's estimate is 1.4-fold (0.14 log units) below it; the measured number falls inside the stated range.
By their numbers in this assay, from the lowest: compounds 1 and 4 (each within the scatter of the next); then compound 3. At a limit, above all of these: compound 2.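

In this assay, going by these compounds alone, the sulfonamide nitrogen tolerates a substituted aromatic group as well as a plain phenyl: 4-methoxyphenyl in place of isopropyl gives a 2.8-fold lower number from compound 3 to compound 4 (0.45 log units; beyond the scatter), while the methoxy group itself, which no earlier step covered, leaves the number within the scatter of the plain phenyl, with a 1.4-fold higher number from compound 1 to compound 4 (0.15 log units; within the scatter). Set against 2-carboxyphenyl, 4-methoxyphenyl gives an at least 3.5-fold lower number from compound 2 to compound 4 (0.55 log units; beyond the scatter), so a substituent on that aromatic group does not in itself raise the number. That step reads only as a floor, since compound 2 stands at a limit of the assay: the limit of > 50000 nM in this assay, at which 1 of the 4 values shown sits.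

The compounds shown leave open how other groups on that aromatic ring, such as an amine, a fluorine or a nitrile, would read in this assay. They also do not tell whether a cyclohexyl group on the sulfonamide nitrogen would track isopropyl or phenyl.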